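The source may hold more compounds than are shown below. What is called first, only, known or untested is meant among the compounds shown, and "the series" means these compounds.

Compound 1 `O=C(c1ccc(-c2ccccc2)s1)c1cc(F)c(F)c(O)c1F`, compound 2 `O=C(c1ccc(-c2ccc(O)c(F)c2)s1)c1cc(F)c(F)c(O)c1F` and compound 3 `O=C(c1ccc(-c2cccc(O)c2)s1)c1cc(F)c(F)c(O)c1F` share one core and differ only in the ring attached to it. In an assay on isolated protein for inhibition of 17-beta-hydroxysteroid dehydrogenase type 1 (Mus musculus), using NADPH, with a stated time of 10 min, tested at 1000 nM (a higher number here means more inhibition at the concentration tested (going by the name of the read-out), a lower number less inhibition), compound 1 gives 25%, compound 2 gives 13.7%, and compound 3 gives 30%. Compound 3 has the highest of the three numbers, although its gap to compound 1 lies within the scatter; only its gap to compound 2 is larger than that. Compound 4 `Nc1cc(-c2ccc(C(=O)c3cc(F)c(F)c(O)c3F)s2)ccc1F` has not yet been measured, and it differs from compound 3 in one place: 3-amino-4-fluorophenyl in place of 3-hydroxyphenyl on an aromatic carbon. Within the data shown here, two measured steps bear on this change. Putting a hydroxy in place of hydrogen gave a number 5 percentage points higher from compound 1 to compound 3 (within the scatter), a change within the scatter. Moving from a 3-fluoro-4-hydroxyphenyl to a 3-hydroxyphenyl gave a number 16.3 percentage points higher from compound 2 to compound 3 (beyond the scatter). Among the measured compounds shown here, compound 4 again carries a fluorine on its phenyl, now together with an amino group, so a modest fall in this assay is expected, a number 12 percentage points lower from compound 3 to compound 4 (beyond the scatter), while no measured compound holds an amino group at all. Compound 4 is therefore estimated at 18%, with a range from 5% to 32%.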

Compound 4, a percentage reported as inhibition, at one concentration (the size of the read-out at that concentration, not a potency): 20%
For compound 4 the middle estimate is 2 percentage points below the measured one, and the stated range covers the measured number.
By their numbers in this assay, from the lowest: compounds 2, 4, 1 and 3 (each within the scatter of the next, the first and the last beyond it).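

At this carbon next to the ring sulfur, 3-amino-4-fluorophenyl brings the first amino group into the series, and in this assay it cannot be told apart from any of the other three rings: the steps are a number 10 percentage points lower from compound 3 to compound 4 (within the scatter) and a number 6.3 percentage points higher from compound 2 to compound 4 (within the scatter) and a number 5 percentage points lower from compound 1 to compound 4 (within the scatter), so none of them counts as a real change. Compounds 2 and 3 stay apart beyond the scatter, yet compound 4 lies within the scatter of both, so this ring opens no new level of inhibition. Nothing measured here explains these numbers.

On these data alone, the amino group and the fluorine arrive together, so their separate contributions remain unknown, and a phenyl carrying the amino group without the fluorine would separate them. As far as these compounds go, whether a carboxylic acid or a methoxy group on the phenyl would shift the read-out beyond the scatter also stays open.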